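Amino for dimethylamino on the shared core

The source may report more compounds than this note shows. Statements on the series, on what has been measured and on what is new or still open speak of the compounds shown alone.

Within the data shown here, compound 3 `CSc1nc(N(C)C)c2ncn([C@@H]3C[C@@H](O)[C@H](CO)O3)c2n1` is the one member with a number in a functional assay on U-937 cells (Homo sapiens) (on this read-out higher numbers stand for weaker inhibition and lower numbers for stronger inhibition), where compound 3 gives 126 uM. Compound 1 `CN(C)c1nc(N)c2ncn([C@@H]3C[C@@H](O)[C@H](CO)O3)c2n1` sits at a limit of this assay, compound 1 giving > 300 uM. Compound 2 `CSc1nc(SC)c2ncn([C@@H]3C[C@@H](O)[C@H](CO)O3)c2n1` likewise sits at a limit, compound 2 giving > 300 uM. Among the measured compounds shown here, the one measured step is an at least 2.3-fold lower number from compound 2 to compound 3 (0.37 log units; beyond the scatter). Compound 4 `CSc1nc(N)c2ncn([C@@H]3C[C@@H](O)[C@H](CO)O3)c2n1` differs from compound 3 by amino in place of dimethylamino on an aromatic carbon. For the measured compounds named here, no measured step covers this change; compound 1, which carries the amino group, rests at the limit (the limit of > 300 uM in this assay, at which 2 of the 3 values shown sit), so a weakening is the more likely outcome, though its size is unknown. The estimated step is a 2.0-fold higher number from compound 3 to compound 4 (0.30 log units; within the scatter), and compound 4 is expected near 250 uM, between 80 uM and 600 uM.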

Compound 4, concentration for 50% inhibition: > 300 uM
Compound 4: no number, only a limit; the forecaster's own chance of this, stated with the estimate: 50%; middle value at least 1.2-fold (0.07 log units) away from the limit.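

In this assay, amino in place of dimethylamino on this aromatic carbon gives an at least 2.3-fold higher number from compound 3 to compound 4 (0.37 log units; beyond the scatter), so the methyl groups on that nitrogen matter to the read-out. Among the groups shown at this position, only the dimethylamino of compound 3 gives a number, and the other compounds stay at a limit: the limit of > 300 uM in this assay, at which 3 of the 4 values shown sit. The steps between two limits cannot be read.

Open, as far as these compounds go, is whether methylamino, with one methyl group, would restore a number. Also open, from the compounds shown here alone, is whether diethylamino would lower the number further.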